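Methoxy placement on the aryl bound to the thiocarbonyl nitrogen

A few compounds are considered here, and "the series" means these few. Any claim that something is new, unique, unknown or untested is made for them only; others in the source may bear on it.

Measured so far in a physicochemical assay for lipophilicity, in phosphate buffer, measured as octanol-water partition; a higher number here means a more lipophilic compound, a lower number a more polar compound: compound 1 `COc1ccc(NC(=S)NC(=O)Nc2ccc3c(c2)C(=O)C(=O)N3Cc2ccccc2)cc1` gives 2.39; compound 2 `Cc1ccc(NC(=S)NC(=O)Nc2ccc3c(c2)C(=O)C(=O)N3Cc2ccccc2Cl)cc1` gives 3.73; compound 3 `COc1cccc(NC(=S)NC(=O)Nc2ccc3c(c2)C(=O)C(=O)N3Cc2ccccc2Cl)c1` gives 3.19.

Compound 3 stands second highest of the three, with compound 2 above it and compound 1 below it, both gaps beyond the scatter. Going by the values given here, the only step that can be followed directly is a number 0.54 log units lower from compound 2 to compound 3 (beyond the scatter), an exchange of the aryl group on the amide-type nitrogen. Compound 4 `COc1ccc(NC(=S)NC(=O)Nc2ccc3c(c2)C(=O)C(=O)N3Cc2ccccc2Cl)cc1` carries 4-methoxyphenyl in place of 3-methoxyphenyl on an amide-type nitrogen. Among the compounds with values here, no measured pair isolates this change; compound 1 shares the 4-methoxyphenyl but differs elsewhere, so its value and that of compound 3 show only that compound 1 lies lower. With the same atoms joined differently, the step of a number 0.09 log units lower from compound 3 to compound 4 (within the scatter) is expected to stay within the scatter. Compound 4 is therefore estimated at 3.1, with a range from 2.7 to 3.5.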

Compound 4, partition coefficient: 3.24
For compound 4 the middle estimate is 0.14 log units below the measured one; the measured number falls inside the stated range.
By their numbers in this assay, from the lowest: compound 1; then compounds 3 and 4 (each within the scatter of the next); then compound 2.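

In this assay putting 4-methoxyphenyl in place of 3-methoxyphenyl on the amide-type nitrogen gives a number 0.05 log units higher from compound 3 to compound 4 (within the scatter) and so does not separate the two methoxy placements. Methoxy in place of methyl on an aromatic carbon gives a number 0.49 log units lower from compound 2 to compound 4 (beyond the scatter) and chloro in place of hydrogen on an aromatic carbon gives a number 0.85 log units higher from compound 1 to compound 4 (beyond the scatter) in this pair. No measurement at hand explains these steps.

Open, on these data alone, is how an aminophenyl or a carboxyphenyl on the same amide-type nitrogen would read. Also open, as far as these compounds go, is whether the two methoxy placements stay level on the core of compound 1.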